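Working notes: amide exchange on the shared core

A few compounds are considered here, and "the series" means these few. Any claim that something is new, unique, unknown or untested is made for them only; others in the source may bear on it.

Measured so far in a physicochemical assay for lipophilicity, read by HPLC, at pH 7.5; a lower number here means a more polar compound, a higher number a more lipophilic compound:
Compound 1 `CCOc1ccccc1-c1ccc(-c2nc3cnccc3c(N[C@@H]3CCOC3=O)c2C#N)cc1` gives 2.7.
Compound 2 `CCOc1ccccc1-c1ccc(-c2nc3cnccc3cc2C#N)cc1` gives 3.8.
Compound 3 `CCOc1ccccc1-c1ccc(-c2nc3cnccc3c(N[C@H](CC)C(=O)NS(C)(=O)=O)c2C#N)cc1` gives 2.2.

Compound 3 stands lowest of the three: a number 0.50 log units lower from compound 1 to compound 3 (beyond the scatter), and a number 1.60 log units lower from compound 2 to compound 3 (beyond the scatter). Compound 4 `CCOc1ccccc1-c1ccc(-c2nc3cnccc3c(N[C@H](CC)C(=O)N(C)C)c2C#N)cc1` is not yet measured. The change is dimethylamino in place of methanesulfonamido on a carbonyl carbon. Both steps into compound 3 bear on it, as the methanesulfonamido that now leaves was part of what entered there and pulled the number down each time; dimethylamino brings no hydrogen-bond donor or acceptor in its place. A step upward beyond the scatter is therefore expected, a number 1.10 log units higher from compound 3 to compound 4 (beyond the scatter), though not back to the level of compound 2. Compound 4 is estimated at 3.3, within 2.7 to 3.9.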

Compound 4, distribution coefficient: 3.7
Compound 4: middle estimate off by 0.40 log units, on the low side; measured number inside the range.
By their numbers in this assay, from the lowest: compound 3; then compound 1; then compounds 4 and 2 (each within the scatter of the next).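

In this assay, the group on the carbonyl carbon alone sets a wide gap, with dimethylamino in place of methanesulfonamido giving a number 1.50 log units higher from compound 3 to compound 4 (beyond the scatter). With dimethylamino there, the full side chain in place of hydrogen gives a number 0.10 log units lower from compound 2 to compound 4 (within the scatter), while 1-(dimethylcarbamoyl)propyl in place of 2-oxooxolan-3-yl gives a number 1.00 log units higher from compound 1 to compound 4 (beyond the scatter). No measurement shown accounts for these steps.

The compounds shown leave open where a carboxylic acid or a primary amide on the same carbonyl carbon would fall relative to compound 3 and compound 4.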